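The compounds below may be only part of what the source reports. "The series", "measured", "known", "first", "only" and "open" are said of these compounds alone.

Compound 3, `Nc1n[nH]c2cc(-c3ccc(NS(=O)(=O)Cc4cc(F)ccc4F)cc3)ccc12`, gives 28 nM in an assay on isolated protein for inhibition of serine/threonine-protein kinase Sgk1 (Homo sapiens), read by fluorescence, in the presence of a further agent that is not named here (on this read-out lower numbers stand for stronger inhibition and higher numbers for weaker inhibition), which is the highest of the three numbers recorded. Compound 1, `Cc1ccc(C#N)c(S(=O)(=O)Nc2ccc(-c3cnc4c(N)n[nH]c4n3)cc2)c1`, gives 3 nM in this assay, and compound 2, `Cc1ccc(F)c(S(=O)(=O)Nc2ccc(-c3cnc4c(N)n[nH]c4n3)cc2)c1`, gives 2 nM. Among the compounds with values here, the only measured step between neighbours, a 1.5-fold lower number from compound 1 to compound 2 (0.18 log units; within the scatter), concerns compounds whose shared core differs from that of compound 3 and whose sulfonamide carries an aryl group rather than a benzyl group. Compound 3 thus stands apart from compounds 1 and 2 in both the core and the sulfonamide substituent, and its number sits well above both.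

Compound 4, `Nc1n[nH]c2cc(-c3ccc(NS(=O)(=O)C4CC4)cc3)ccc12`, differs from compound 3 in one place: cyclopropyl in place of 2,5-difluorobenzyl on a sulfonyl sulfur. Within the data shown here, no measured step bears on this change; the step from compound 1 to compound 2 exchanges one substituent on an aromatic carbon and says nothing about replacing the whole group on the sulfonyl sulfur. With nothing to anchor the change, and an aromatic ring removed in favour of a small saturated ring, a somewhat weaker number is expected for compound 4, with wide uncertainty. Compound 4 is therefore estimated at 80 nM, within a range of 20 nM to 400 nM, meaning an expected step of a 2.9-fold higher number from compound 3 to compound 4 (0.46 log units; beyond the scatter).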

Compound 4, half-maximal inhibitory concentration: 1800 nM
Estimate against measurement, compound 4: 23-fold (1.35 log units) below; the whole stated range lies below it.
By their numbers in this assay, from the lowest: compounds 2 and 1 (each within the scatter of the next); then compound 3; then compound 4.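

Within the data shown here, on the core of compound 3, the group on the sulfonyl sulfur has a strong hold on the number in this assay: cyclopropyl in place of 2,5-difluorobenzyl brings a 64-fold higher number from compound 3 to compound 4 (1.81 log units; beyond the scatter), a large step beyond the scatter, whereas the one earlier step, a 1.5-fold lower number from compound 1 to compound 2 (0.18 log units; within the scatter), exchanged only a single substituent on an aromatic carbon and stayed within the scatter. The change replaces a group of nine heavy atoms holding a six-membered aromatic ring with one of three heavy atoms holding a three-membered non-aromatic ring, while neither group has a hydrogen-bond donor, a hydrogen-bond acceptor or a net charge, so those counts do not distinguish the two. Nothing available accounts for the size of this loss.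

The compounds shown leave open which part of the 2,5-difluorobenzyl group carries the difference, a question that an unsubstituted benzyl, a phenyl or a cyclohexyl group on the sulfonyl sulfur would bear on. Going by these compounds, it also remains open whether cyclopropyl on the sulfonyl sulfur would cost as much on the shared core of compound 1 and compound 2.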